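The source may report more compounds than this note shows. Statements on the series, on what has been measured and on what is new or still open speak of the compounds shown alone.

Compounds measured in a functional assay on HeLa cells (Homo sapiens) for antiproliferative activity, read by XTT assay, with a stated time of 72 h; on this read-out higher numbers stand for weaker inhibition and lower numbers for stronger inhibition:

Compound 1 `C=C(C)CCC[C@]1(C)C2=CCC[C@](C)(CC(=O)c3ccoc3)[C@H]2CC[C@H]1C` gives > 100000 nM, which is a limit of the assay, not a number.
Compound 2 `C=C(C)CC[C@]1(C)C2=CCC[C@](C)(C[C@@H](O)c3ccoc3)[C@H]2CC[C@H]1C` gives 30200 nM.
Compound 3 `C=C(C)CCC[C@]1(C)C2=CCC[C@](C)(C[C@H](O)c3ccoc3)[C@H]2CC[C@H]1C` gives 59400 nM.

Among the compounds with values here, compound 3 and compound 2 give numbers that lie within the usual scatter of each other, and the only other value shown, that of compound 1, is a limit. Within the data shown here, the one step that joins two measured compounds runs an at least 1.6-fold lower number from compound 1 to compound 3 (0.22 log units; that floor lies within the scatter), putting (furan-3-yl)(hydroxy)methyl in place of (furan-3-yl)carbonyl on a saturated chain carbon bound to a saturated ring carbon; its size is known only as a floor because of the limit of > 100000 nM in this assay, at which 1 of the 3 values shown sits.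

Compound 4 `C=C(C)CCC[C@]1(C)C2=CCC[C@](C)(C[C@H](O)C3=CC(=O)OC3O)[C@H]2CC[C@H]1C` differs from compound 3 by a group of 7 heavy atoms (4 carbon, 3 oxygen; one five-membered non-aromatic ring with 1 hetero atom) in place of a group of 5 heavy atoms (4 carbon, 1 oxygen; one five-membered aromatic ring with 1 hetero atom), on a saturated chain carbon bound to an oxygen on a saturated carbon and a saturated chain carbon. Among the measured compounds shown here, no measured step touches the furan-3-yl group itself, so there is nothing to set a direction for this change; the one step known is modest and at a different place. The expectation is therefore a step of a 1.3-fold lower number from compound 3 to compound 4 (0.12 log units; within the scatter), which is within the scatter. Compound 4 is estimated at 45000 nM, with a range from 12000 nM to 150000 nM.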

Compound 4, half-maximal inhibitory concentration: 3800 nM
For compound 4 the middle estimate is 12-fold (1.07 log units) above the measured one; the measured number lies below the stated range.
By their numbers in this assay, from the lowest: compound 4; then compounds 2 and 3 (each within the scatter of the next). At a limit, above all of these: compound 1.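

In this assay, the earlier step of an at least 1.6-fold lower number from compound 1 to compound 3 (0.22 log units; that floor lies within the scatter) showed no change that could be told from scatter, whereas replacing furan-3-yl with the new five-membered non-aromatic ring gives a 16-fold lower number from compound 3 to compound 4 (1.19 log units; beyond the scatter). This is the first sign among these compounds that the group on this saturated chain carbon, bound to an oxygen on a saturated carbon and a saturated chain carbon, can move the number well beyond the scatter. The wider step, which also changes carbonyl to hydroxy-bearing carbon, gives an at least 26-fold lower number from compound 1 to compound 4 (1.42 log units; beyond the scatter), and its size is only a floor: the limit of > 100000 nM in this assay, at which 1 of the 4 values shown sits.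

The single swap changes several things at once, including the ring's aromatic character, its double bonds outside aromatic rings and its hydrogen-bond donor and acceptors, so the compounds shown cannot say which of these matters. A close analogue carrying a methoxy group or an amine in place of the hydroxyl on the new ring would help separate these features, and the same ring on the shorter chain of compound 2 would test whether the large step carries over.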